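From acetyl(methyl)amino to 3-oxomorpholin-4-yl on a shared core

The compounds below may be only part of what the source reports. "The series", "measured", "known", "first", "only" and "open" are said of these compounds alone.

Two compounds measured in an ADME assay on microsomes from liver (Rattus norvegicus) for metabolic stability, read by LC-MS, using NADPH, with a stated time of 30 min, tested at 1 uM (a higher number here means faster removal of the compound, a lower number slower removal), so far
compound 1 `CC(C)c1noc(N2CCC(Oc3cc(N4CCc5cc(N6CCCCC6=O)ccc54)ncn3)CC2)n1` - 13 mL.min-1.g-1
compound 2 `CC(=O)N(C)c1ccc2c(c1)CCN2c1cc(OC2CCN(c3nc(C(C)C)no3)CC2)ncn1` - 17 mL.min-1.g-1

Compound 2 stands level with compound 1, the two values lying within the scatter of each other. Compound 3 `CC(C)c1noc(N2CCC(Oc3cc(N4CCc5cc(N6CCOCC6=O)ccc54)ncn3)CC2)n1` comes from compound 2 by a single change, (3-oxomorpholin-4-yl in place of acetyl(methyl)amino on an aromatic carbon), which puts 3-oxomorpholin-4-yl in place of acetyl(methyl)amino on an aromatic carbon. Among the compounds with values here, one measured step bears on this place. It is a 1.3-fold higher number from compound 1 to compound 2 (0.12 log units; within the scatter) for acetyl(methyl)amino in place of 2-oxopiperidin-1-yl on an aromatic carbon, and it stays within the scatter. Within the data shown here, no measurement yet shows 3-oxomorpholin-4-yl itself, so this single small step is the only guide. No step beyond the scatter is therefore expected in this assay for the new group. The expected change is a 1.3-fold lower number from compound 2 to compound 3 (0.12 log units; within the scatter) and no firm direction is claimed for it. Compound 3 is estimated at 13 mL.min-1.g-1 in this assay, with an expected range from 6.5 mL.min-1.g-1 to 26 mL.min-1.g-1 for the measurement still to come.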

Compound 3, intrinsic clearance in microsomes in the Rattus norvegicus assay: 46 mL.min-1.g-1
The estimate for compound 3 lay 3.5-fold (0.55 log units) below the measured number; the measured number lies above the stated range.
By their numbers in the Rattus norvegicus assay, from the lowest: compounds 1 and 2 (each within the scatter of the next); then compound 3.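

In the Rattus norvegicus assay this aromatic carbon turns out not to be indifferent to the group it carries: the earlier exchange gave only a 1.3-fold higher number from compound 1 to compound 2 (0.12 log units; within the scatter), whereas 3-oxomorpholin-4-yl gives a 2.7-fold higher number from compound 2 to compound 3 (0.43 log units; beyond the scatter) and, against the other amide-bearing group, a 3.5-fold higher number from compound 1 to compound 3 (0.55 log units; beyond the scatter). So 2-oxopiperidin-1-yl and acetyl(methyl)amino stand level in the Rattus norvegicus assay, while 3-oxomorpholin-4-yl, the one group of the three with a ring holding 2 hetero atoms, stands apart from both with faster removal. In a physicochemical assay for lipophilicity, measured as octanol-water partition, at pH 7.4 (a lower number here means a more polar compound, a higher number a more lipophilic compound), compound 2 gives 3.7 and compound 3 gives 3.1. That faster removal does not come with a rise in lipophilicity, since in the physicochemical assay compound 3 is the more polar of the pair: the measured distribution coefficient of compound 2, 3.7, and of compound 3, 3.1, a number 0.60 log units lower (beyond the scatter)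

With only three groups at this place, the compounds shown cannot say whether the oxygen within the ring of 3-oxomorpholin-4-yl alone accounts for the step, or what a smaller lactam such as 2-oxopyrrolidin-1-yl or a ring carrying an amine such as 4-methylpiperazin-1-yl would do in the Rattus norvegicus assay. As far as these compounds go, whether the same exchange gives a similar step on any core other than the shared one also stays open.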